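Swapping the amide aryl group of compound 1

A few compounds are considered here, and "the series" means these few. Any claim that something is new, unique, unknown or untested is made for them only; others in the source may bear on it.

Compound 1 `COc1ccc(NC(=O)CN2CCN(c3nnc(Cc4ccncc4)c4ccccc34)CC2)cc1OC` is the reference point here. Among the measured compounds shown here, in a functional assay on MDA-MB-231 cells (Homo sapiens) for cytotoxicity, read by MTT assay, with a stated time of 72 h (a higher number here means a weaker inhibitor, a lower number a stronger inhibitor), compound 1 gives 100 nM, the lowest number among the three compounds measured so far. Two related compounds carry a benzyl group on the shared core instead of the pyridinylmethyl group of compound 1 and differ in the aryl ring on the amide nitrogen. For the measured compounds named here, compound 2 `Cc1ccc(F)cc1NC(=O)CN1CCN(c2nnc(Cc3ccccc3)c3ccccc23)CC1` gives 19200 nM, and compound 3 `O=C(CN1CCN(c2nnc(Cc3ccccc3)c3ccccc23)CC1)Nc1ccc(F)c(F)c1` gives 2750 nM; the one step between them, a 7.0-fold lower number from compound 2 to compound 3 (0.84 log units; beyond the scatter), shows that the aryl group on the amide nitrogen alone can move the number well beyond the scatter.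

Compound 4 `O=C(CN1CCN(c2nnc(Cc3ccncc3)c3ccccc23)CC1)Nc1cc(C(F)(F)F)ccc1Cl` keeps the pyridinylmethyl core of compound 1 and changes only the amide aryl group: 2-chloro-5-(trifluoromethyl)phenyl in place of 3,4-dimethoxyphenyl on an amide-type nitrogen. Going by the values given here, no measured pair shows this exact exchange, and the step between compound 2 and compound 3 concerns different aryl groups. Since both fluorinated aryl rings gave far higher numbers than the dimethoxyphenyl of compound 1, a moderate rise is expected, giving a 10-fold higher number from compound 1 to compound 4 (1.00 log units; beyond the scatter). Compound 4 is thus estimated at 1000 nM, with a range from 200 nM to 8000 nM.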

Compound 4, half-maximal inhibitory concentration: 3.7 nM
Estimate against measurement, compound 4: 270-fold (2.43 log units) above; measured number outside the range, below it.
By their numbers in this assay, from the lowest: compound 4; then compound 1; then compound 3; then compound 2.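

Exchanging the amide aryl group on the core of compound 1 gives a 27-fold lower number from compound 1 to compound 4 (1.43 log units; beyond the scatter) in this assay, so 3,4-dimethoxyphenyl does not mark the low end of what this position can reach. The 2-chloro-5-(trifluoromethyl)phenyl group has 0 hydrogen-bond acceptors where 3,4-dimethoxyphenyl has 2, so those acceptors are not needed for a low number on this core. Among the compounds shown here, nothing measured here explains why this exchange lowers the number so far.

For the compounds shown here, the effects of the chlorine and the trifluoromethyl group cannot be separated, as each arrives only with the other, and no pair shows whether the same aryl group would act alike on the benzyl core of compound 2 and compound 3. Going by these compounds, how an aryl ring carrying an amine or a carboxylic acid would behave at this position also remains open.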